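The source may report more compounds than this note shows. Statements on the series, on what has been measured and on what is new or still open speak of the compounds shown alone.

Compound 1 `COc1ccc(-c2cc(NC(=O)c3ccc(OC)cc3O)c[nH]c2=O)cc1`: 49900 nM
Compound 2 `COc1ccc(-c2cc(NC(=O)c3cccc(OC)c3O)c[nH]c2=O)cc1`: 49200 nM

In an ADME assay on HepG2 2.2.15 cells (Homo sapiens) for cytotoxicity, read by CCK-8 assay, with a stated time of 8 days (on this read-out higher numbers stand for lower toxicity in this test and lower numbers for higher toxicity in this test), compound 2 gives 49200 nM, level with compound 1 at 49900 nM. Compound 3 `COc1ccc(-c2cc(NC(=O)c3ccc(Cl)cc3O)c[nH]c2=O)cc1` carries 4-chloro-2-hydroxyphenyl in place of 2-hydroxy-3-methoxyphenyl on a carbonyl carbon. Among the measured compounds shown here, the only measured step that bears on this is a 1.0-fold lower number from compound 1 to compound 2 (0.01 log units; within the scatter), an exchange of 2-hydroxy-4-methoxyphenyl for 2-hydroxy-3-methoxyphenyl. For the measured compounds named here, no measured compound carries 4-chloro-2-hydroxyphenyl, so the evidence is thin, and no step beyond the scatter is expected in this assay. The expected step is a 1.1-fold lower number from compound 2 to compound 3 (0.04 log units; within the scatter). For compound 3 the estimated value is 45000 nM, with an expected range of 20000 nM to 85000 nM.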

Compound 3, half-maximal cytotoxic concentration: 50500 nM
Beside the measured number, compound 3's estimate is 1.1-fold (0.05 log units) below it, within the range that was stated.
By their numbers in this assay, from the lowest: compounds 2, 1 and 3 (each within the scatter of the next).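

Replacing methoxy with chloro on an aromatic carbon gives a 1.0-fold higher number from compound 1 to compound 3 (0.01 log units; within the scatter) in this assay, and 4-chloro-2-hydroxyphenyl in place of 2-hydroxy-3-methoxyphenyl on a carbonyl carbon gives a 1.0-fold higher number from compound 2 to compound 3 (0.01 log units; within the scatter) as well. The earlier pair showed only a methoxy group changing place, whereas here the methoxy group itself is exchanged and the reading stays level. Nothing measured here bears on the cause of this.

As far as these compounds go, whether an amine, a carboxylic acid or a longer alkoxy chain on this ring would also leave the reading level remains open.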